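The compounds below may be only part of what the source reports. "The series", "measured", "known", "first", "only" and "open" are said of these compounds alone.

Working notes on a small set of thiadiazole carboxamide acids bearing a propanoic acid chain, all tested in a functional assay on CHO cells for agonist activity at Free fatty acid receptor 1 (Homo sapiens), read by calcium flux; a higher number here means that more compound is needed for the effect, a lower number that less compound is needed. Compound 1 `Cc1cccc(-c2cccc(NC(=O)c3nnc(CCC(=O)O)s3)c2)c1` gives 760 nM in this assay. Compound 2 `O=C(O)CCc1nnc(C(=O)Nc2ccc(OCc3ccccc3)cc2)s1` gives 17900 nM in this assay. Compound 3 `O=C(O)CCc1ccc(OCc2nnc(C(=O)Nc3ccccc3)s2)cc1` gives 1060 nM in this assay. On these three numbers compound 3 stands second highest; its nearest neighbour is compound 1, whose number sits within the usual scatter of that of compound 3, so no order between the two can be read; its furthest is compound 2, whose number lies beyond the scatter above that of compound 3.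

The next step keeps the core and the chain of compound 3 and alters only the anilide ring: compound 4 `Cc1cccc(NC(=O)c2nnc(COc3ccc(CCC(=O)O)cc3)s2)c1` differs from compound 3 by methyl in place of hydrogen on an aromatic carbon, meta to a large group. Within the data shown here, no measured pair in the set carries this same change, so the size of the step cannot be taken from the set; a change of this kind is expected to lie within or only slightly beyond the scatter, with a slight lean toward a lower number. For compound 4 the expected result in this assay is 750 nM, with a likely range from 250 nM to 2500 nM. The step from compound 3 to compound 4 is thus estimated as a 1.4-fold lower number from compound 3 to compound 4 (0.15 log units; within the scatter).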

Compound 4, half-maximal effective concentration: 1770 nM
The estimate for compound 4 lay 2.4-fold (0.37 log units) below the measured number; the measured number falls inside the stated range.
By their numbers in this assay, from the lowest: compounds 1, 3 and 4 (each within the scatter of the next, the first and the last beyond it); then compound 2.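

In this assay, the change from phenyl to 3-methylphenyl, with methyl in place of hydrogen on an aromatic carbon meta to a large group, gives a 1.7-fold higher number from compound 3 to compound 4 (0.22 log units; within the scatter). Among these compounds, this is the first pair that differs in one place, and it shows that this position of the anilide ring carries a methyl group with no step that can be told apart from the usual scatter. The pair offers a single reading at a single position, and no measurement at hand bears on what lies behind it.

Going by these compounds, it remains open whether a larger or different group at this same position, such as a chlorine atom, a methoxy group or a trifluoromethyl group, would give a step beyond the scatter, and whether a methyl group on another carbon of this ring would read the same. On these data alone, it is also open whether the phenyl to 3-methylphenyl change would give a similar step on the arrangement of compound 2, where the propanoic acid chain sits directly on the shared core.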